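A few compounds are considered here, and "the series" means these few. Any claim that something is new, unique, unknown or untested is made for them only; others in the source may bear on it.

Of the compounds shown here, three built on a shared core have been measured in a functional assay on HEK293 cells for agonist activity at G-protein coupled receptor 39 (Homo sapiens), read by scintillation proximity assay and inositol phosphate accumulation, with a stated time of 75 min; a higher number here means that more compound is needed for the effect, a lower number that less compound is needed. Compound 1 `Cc1nn(-c2ncnc3nc[nH]c23)c2c1C(C(=O)NCc1ccc(F)cc1)CC(=O)N2` gives 1220 nM, compound 2 `Cc1cc(C)n(CCOC2CC(=O)Nc3c2c(C)nn3-c2ncnc3nc[nH]c23)n1` gives 2000 nM, and compound 3 `Cc1cc(C)nc(-n2nc(C)c3c2NC(=O)CC3c2ccc(COc3cccc(Cl)c3)cc2)n1` gives 3000 nM. Compound 2 holds the second highest of these three numbers, yet its gaps to compound 3 and to compound 1 both lie within the scatter, so no order can be read among them. Compound 4 `Cc1nn(-c2ncnc3nc[nH]c23)c2c1C(OCCn1nccc1C)CC(=O)N2` departs from compound 2 by a single change, (hydrogen in place of methyl on an aromatic carbon), hydrogen in place of methyl on an aromatic carbon. Among the compounds with values here, no measured pair shows this step. A change this small is expected to move the number no further than the scatter in either direction, and the estimated step is no change at the digits printed from compound 2 to compound 4 (within the scatter). Compound 4 is therefore expected to give 2000 nM in this assay, between 900 nM and 4500 nM.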

Compound 4, half-maximal effective concentration: 1620 nM
Compound 4: middle estimate off by 1.2-fold (0.09 log units), on the high side; the measured number falls inside the stated range.
By their numbers in this assay, from the lowest: compounds 1, 4, 2 and 3 (each within the scatter of the next, the first and the last beyond it).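

In this assay, within the data shown here, going from 3,5-dimethyl-1H-pyrazol-1-yl to 5-methyl-1H-pyrazol-1-yl gives a 1.2-fold lower number from compound 2 to compound 4 (0.09 log units; within the scatter), the first step here between compounds that differ in one place. At this position, then, hydrogen stands in place of methyl with no shift that can be told from the scatter. No evidence on hand explains this result. The compounds shown carry only hydrogen or methyl at this place, so what a chlorine, an amine or a longer chain would do there remains open. Going by these compounds, whether the 5-methyl group can also give way to hydrogen remains open as well.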